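A few compounds are considered here, and "the series" means these few. Any claim that something is new, unique, unknown or untested is made for them only; others in the source may bear on it.

Among the measured compounds shown here, compound 2 `CC(C)(Oc1ccccc1Br)C1OCC(C/C=C\CCC(=O)O)C(c2cccnc2)O1` is one of two compounds measured in an assay for inhibition of Thromboxane-A synthase (Homo sapiens), using microsomes (a higher number here means a weaker inhibitor, a lower number a stronger inhibitor), where compound 2 gives 29 nM. Its companion, compound 1 `CSc1ccccc1OC(C)(C)C1OCC(C/C=C\CCC(=O)O)C(c2cccnc2)O1`, carries methylsulfanyl where compound 2 carries bromo, and in this assay compound 1 gives 36 nM; the step of a 1.2-fold lower number from compound 1 to compound 2 (0.09 log units; within the scatter), so the two numbers cannot be told apart.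

Compound 3 `CC(C)(Cc1ccccc1)C1OCC(C/C=C\CCC(=O)O)C(c2cccnc2)O1` is not yet measured. It differs from compound 2 by benzyl in place of 2-bromophenoxy on a saturated chain carbon bound to two saturated chain carbons and a saturated ring carbon. For the measured compounds named here, only the step from compound 1 to compound 2 bears on this change, and only loosely: it swapped one group on the aromatic ring for another and stayed within the scatter, whereas in compound 3 the ring loses its substituent and its linking oxygen together. Going by the values given here, no measured step covers that loss, so a modest weakening is expected at most, with wide uncertainty: compound 3 is estimated at 60 nM, between 15 nM and 250 nM, an expected step of a 2.1-fold higher number from compound 2 to compound 3 (0.32 log units; beyond the scatter).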

Compound 3, half-maximal inhibitory concentration: 12 nM
Beside the measured number, compound 3's estimate is 5.0-fold (0.70 log units) above it; measured number below the stated range.
By their numbers in this assay, from the lowest: compound 3; then compounds 2 and 1 (each within the scatter of the next).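

Putting benzyl on this saturated chain carbon lowers the number relative to both phenoxy compounds (a 2.4-fold lower number from compound 2 to compound 3 (0.38 log units; beyond the scatter)) (a 3.0-fold lower number from compound 1 to compound 3 (0.48 log units; beyond the scatter)). Unlike the swap of groups on the aromatic ring between compound 1 and compound 2, these steps lie beyond the scatter, so this change does move the number, and a ring with no substituent, joined through carbon with no oxygen, still gives a low number. Nothing at hand explains the drop.

The step to compound 3 removes the ring substituent and swaps the linking oxygen for carbon together, so the compounds shown cannot say which of the two changes matters. An unsubstituted phenoxy group and a 2-bromobenzyl group would pull these two changes apart, while a linking amine would test another atom in that place.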